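The source may report more compounds than this note shows. Statements on the series, on what has been measured and on what is new or still open speak of the compounds shown alone.

In a functional assay on PC-3 cells (Homo sapiens) for inhibition, read by CellTiter-Glo, with a stated time of 72 h (a lower number here means that less compound is tolerated, a higher number that more compound is tolerated), compound 1 `CC1=C(CC(=O)N(C)CCN(C)C(=O)[C@@H](N)C(C)C)c2cc(F)ccc2/C1=C\c1ccc([S+](C)[O-])cc1` is reported as > 50000 nM, which is a limit of the assay. Compound 2 `CC1=C(CC(=O)N(C)CCN(C)S(C)(=O)=O)c2cc(F)ccc2/C1=C\c1ccc([S+](C)[O-])cc1` gives 42600 nM. Among the compounds with values here, compound 3 `CC1=C(CC(=O)N(C)CCN(C)S(=O)(=O)c2ccccc2)c2cc(F)ccc2/C1=C\c1ccc([S+](C)[O-])cc1` gives 8200 nM, the lowest number so far. Compound 4 `CC1=C(CC(=O)N(C)CCN(C)S(=O)(=O)c2cccc3ccccc23)c2cc(F)ccc2/C1=C\c1ccc([S+](C)[O-])cc1` differs from compound 3 in one place: naphthalen-1-yl in place of phenyl on a sulfonyl sulfur. Within the data shown here, the closest precedent is a 5.2-fold lower number from compound 2 to compound 3 (0.72 log units; beyond the scatter), where phenyl replaced methyl on the same sulfonyl sulfur. The wider comparison, an at least 6.0-fold lower number from compound 1 to compound 3 (0.78 log units; beyond the scatter), involves a different change and rests on a limit. This single precedent supports only a cautious expectation of a further fall in this assay, with an estimated size of a 2.3-fold lower number from compound 3 to compound 4 (0.37 log units; beyond the scatter). For compound 4 the expected value is 3500 nM, with an estimated range from 1200 nM to 10000 nM.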

Compound 4, half-maximal cytotoxic concentration: 8960 nM
Estimate against measurement, compound 4: 2.6-fold (0.41 log units) below; the measured number falls inside the stated range.
By their numbers in this assay, from the lowest: compounds 3 and 4 (each within the scatter of the next); then compound 2. At a limit, above all of these: compound 1.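

In this assay, within the data shown here, the second aromatic ring brings no further step on this sulfonyl sulfur: a 1.1-fold higher number from compound 3 to compound 4 (0.04 log units; within the scatter). Going from one six-membered aromatic ring to two therefore does not separate these compounds, which the earlier methyl-to-phenyl step could not show. Naphthalen-1-yl stands apart from methyl much as phenyl does, with a 4.8-fold lower number from compound 2 to compound 4 (0.68 log units; beyond the scatter). The compounds shown leave open whether a pyridinyl ring or a longer alkyl chain on this sulfur would fall with methyl or with the aromatic carbon rings. Nothing measured here accounts for the flat step.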